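Loss of the amino group on the core of compound 1

A few compounds are considered here, and "the series" means these few. Any claim that something is new, unique, unknown or untested is made for them only; others in the source may bear on it.

Compound 1 `Nc1nc(Cl)c2ncn(Cc3ccccc3CCl)c2n1` is the weakest grower inhibitor of the three measured compounds: in a functional assay on Hs-578T cells (Homo sapiens) for cytotoxicity, read by sulforhodamine B assay, with a stated time of 48 h (a lower number here means a stronger inhibitor of growth, a higher number a weaker inhibitor of growth), compound 1 gives 7760 nM, while compound 2 `ClCc1cccc(Cn2cnc3nc(Cl)nc(Cl)c32)c1` gives 1410 nM and compound 3 `ClCc1ccccc1Cn1cnc2ncnc(Cl)c21` gives 2290 nM, both steps to compound 1 lying beyond the scatter. Compound 4 `ClCc1ccccc1Cn1cnc2c(Cl)ncnc21` has not yet been measured. It differs from compound 1 by hydrogen in place of amino on an aromatic carbon, the change sitting on an aromatic carbon between two ring nitrogen atoms, meta to a chloro group. Within the data shown here, no measured pair shows this exact change, so its size is not known from a direct step. Given that compound 2 and compound 3, which both lack the amino group, give lower numbers than compound 1, a moderate drop in number is expected for compound 4, a 3.1-fold lower number from compound 1 to compound 4 (0.49 log units; beyond the scatter), though a result within the scatter of compound 1 cannot be ruled out. The estimate for compound 4 in this assay is 2500 nM, with a range from 800 nM to 8000 nM.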

Compound 4, concentration for 50% growth inhibition: 2290 nM
Beside the measured number, compound 4's estimate is 1.1-fold (0.04 log units) above it; the range from low to high includes it.
By their numbers in this assay, from the lowest: compounds 2, 3 and 4 (each within the scatter of the next); then compound 1.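

In this assay, the amino group on the aromatic carbon between two ring nitrogen atoms now has a direct step of its own: a 3.4-fold lower number from compound 1 to compound 4 (0.53 log units; beyond the scatter). Hydrogen in place of amino therefore does not cost growth inhibition on these cells, and the amino group is not required at this position for the activity of compound 4, which gives 2290 nM. Nothing at hand accounts for the size or direction of this step.

The compounds shown compare only amino and hydrogen here, so it remains open whether a methyl, a methoxy or a dimethylamino group at this carbon would track the hydrogen or the amino result. As far as these compounds go, the step also rests on a single pair, and whether it carries over to other substitution on the shared core remains unknown.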